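A few compounds are considered here, and "the series" means these few. Any claim that something is new, unique, unknown or untested is made for them only; others in the source may bear on it.

Measured in a functional assay on HL-60 cells (Homo sapiens) for cytotoxicity, read by WST assay, with a stated time of 48 h; on this read-out higher numbers stand for an effect only at larger amounts of compound and lower numbers for an effect already at smaller amounts:
- Compound 1 `O=C1OC[C@H](Cc2ccccc2)[C@H]1Cc1ccccc1`: 77000 nM
- Compound 2 `O=C1OC[C@H](Cc2ccccc2)[C@H]1Cc1ccc(OC(F)(F)F)cc1`: 27000 nM
- Compound 3 `CCCCOc1ccc(C[C@H]2C(=O)OC[C@@H]2Cc2ccccc2)cc1`: 23000 nM

Compound 3, at 23000 nM, lies clearly below compound 1 and level with compound 2. Compound 4 `O=C1OC[C@H](Cc2ccccc2)[C@H]1Cc1ccc(C(F)(F)F)cc1` carries trifluoromethyl in place of butoxy on an aromatic carbon, para to a large group (trifluoromethyl in place of butoxy on an aromatic carbon). Two modest steps bear on this, each replacing hydrogen at that place: a 2.9-fold lower number from compound 1 to compound 2 (0.46 log units; beyond the scatter) and a 3.3-fold lower number from compound 1 to compound 3 (0.52 log units; beyond the scatter). Butyl in place of trifluoromethyl on an oxygen changed little: a 1.2-fold lower number from compound 2 to compound 3 (0.07 log units; within the scatter). In this assay, no step beyond the scatter is therefore expected, and the estimated change is a 1.3-fold higher number from compound 3 to compound 4 (0.12 log units; within the scatter). For compound 4 the estimated value is 30000 nM, with an expected range of 14000 nM to 60000 nM.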

Compound 4, half-maximal effective concentration: 22000 nM
Beside the measured number, compound 4's estimate is 1.4-fold (0.13 log units) above it; the range from low to high includes it.
By their numbers in this assay, from the lowest: compounds 4, 3 and 2 (each within the scatter of the next); then compound 1.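

In this assay an oxygen attached to the ring is not required on this aromatic carbon, para to a large group: trifluoromethyl in place of butoxy gives a 1.0-fold lower number from compound 3 to compound 4 (0.02 log units; within the scatter) and in place of trifluoromethoxy gives a 1.2-fold lower number from compound 2 to compound 4 (0.09 log units; within the scatter). Against hydrogen, trifluoromethyl gives a 3.5-fold lower number from compound 1 to compound 4 (0.54 log units; beyond the scatter). Butoxy, trifluoromethoxy and trifluoromethyl therefore stand level, and among these compounds what counts is that hydrogen is replaced, not which of the three enters.

As far as these compounds go, whether an amine, a carboxylic acid or a longer chain here would stay level remains open. Nothing available accounts for this levelling.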